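The source may report more compounds than this note shows. Statements on the series, on what has been measured and on what is new or still open speak of the compounds shown alone.

Compound 2 `Cc1n[nH]cc1Nc1nc(N)c2c(C#N)c(N3CCC[C@H]3C)n(C)c2n1` gives 27 nM in an assay on isolated protein for inhibition of Leucine-rich repeat serine/threonine-protein kinase 2 variant G2019S (Homo sapiens), read by TR-FRET and LanthaScreen, with stated times of 50 min and 30 min, in the presence of a further agent that is not named here (a higher number here means a weaker inhibitor, a lower number a stronger inhibitor), the highest of the two numbers shown, while compound 1 `Cc1nn(C2COC2)cc1Nc1nc(N)c2c(C#N)c(N3CCC[C@H]3C)n(C)c2n1` with 25 nM sits within the scatter of it. Compound 3 `Cc1nn(CC2(O)COC2)cc1Nc1nc(N)c2c(C#N)c(N3CCC[C@H]3C)n(C)c2n1` has not yet been measured. Its change from compound 2 is (3-hydroxyoxetan-3-yl)methyl in place of hydrogen on an aromatic nitrogen. Among the measured compounds shown here, the one measured step that bears on this, a 1.1-fold higher number from compound 1 to compound 2 (0.03 log units; within the scatter), removed oxetan-3-yl from that same nitrogen and stayed within the scatter. For compound 3 a step of a 1.1-fold lower number from compound 2 to compound 3 (0.03 log units; within the scatter) is expected, not beyond the scatter in either direction. Compound 3 is therefore estimated at 25 nM, with a range from 12 nM to 55 nM.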

Compound 3, half-maximal inhibitory concentration: 51 nM
Compound 3: middle estimate off by 2.0-fold (0.31 log units), on the low side; the measured number falls inside the stated range.
By their numbers in this assay, from the lowest: compounds 1, 2 and 3 (each within the scatter of the next, the first and the last beyond it).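

At this aromatic nitrogen, the larger (3-hydroxyoxetan-3-yl)methyl group causes no clear loss against hydrogen in this assay: the result is a 1.9-fold higher number from compound 2 to compound 3 (0.28 log units; within the scatter). Against oxetan-3-yl, the same group gives a 2.0-fold higher number from compound 1 to compound 3 (0.31 log units; beyond the scatter), the first sign that the choice of group on this nitrogen can matter, though only modestly. Nothing available explains this difference. Still open, going by these compounds, is whether a simple methyl group or a longer chain ending in an amine or a carboxylic acid would stay close to compound 1 or move further from it.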